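Quinazoline series: arylamino in place of piperidinyl

The compounds below may be only part of what the source reports. "The series", "measured", "known", "first", "only" and "open" are said of these compounds alone.

Measured so far:
compound 1 `FC(F)(F)c1ccc(CSc2nc(N3CCCCC3)c3ccccc3n2)cc1` — 18600 nM
compound 2 `O=[N+]([O-])c1cccc(Nc2nc(SCc3ccc(C(F)(F)F)cc3)nc3ccccc23)c1` — > 50000 nM

Within the data shown here, compound 1 `FC(F)(F)c1ccc(CSc2nc(N3CCCCC3)c3ccccc3n2)cc1` is the only compound of the pair with a measured number in a functional assay on MGC-803 cells (Homo sapiens) for cytotoxicity, read by MTT assay, with a stated time of 72 h; on this read-out lower numbers stand for stronger inhibition and higher numbers for weaker inhibition: compound 1 gives 18600 nM. Compound 2 `O=[N+]([O-])c1cccc(Nc2nc(SCc3ccc(C(F)(F)F)cc3)nc3ccccc23)c1` reaches only a limit of this assay, > 50000 nM, so for compound 2 no number is known. Among the measured compounds shown here, the one measured step, an at least 2.6-fold higher number from compound 1 to compound 2 (0.42 log units; beyond the scatter), is therefore itself only a lower bound, set by the limit of > 50000 nM in this assay, at which 1 of the 2 values shown sits.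

The unmeasured compound 3 `Fc1ccc(Nc2nc(SCc3ccc(C(F)(F)F)cc3)nc3ccccc23)cc1` differs from compound 1 in the same position and in the same manner: (4-fluorophenyl)amino in place of piperidin-1-yl on an aromatic carbon. For the measured compounds named here, an arylamino group again replaces piperidin-1-yl, and the only step that bears on this, an at least 2.6-fold higher number from compound 1 to compound 2 (0.42 log units; beyond the scatter), went towards weaker inhibition and beyond the scatter. A step of similar direction and at least modest size is expected here, with a real chance that this assay again reports only a limit.

Compound 3 is expected at 40000 nM, with a range of 15000 nM to 100000 nM. That expectation corresponds to a 2.2-fold higher number from compound 1 to compound 3 (0.33 log units; beyond the scatter).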

Compound 3, half-maximal inhibitory concentration: 9620 nM
Compound 3: middle estimate off by 4.2-fold (0.62 log units), on the high side; measured number outside the range, below it.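

In this assay, (4-fluorophenyl)amino in place of piperidin-1-yl gives a 1.9-fold lower number from compound 1 to compound 3 (0.29 log units; within the scatter), so an arylamino group at this position does not by itself bring the loss that compound 2 had suggested. The two arylamino compounds instead part on the ring carried by the nitrogen, with 4-fluorophenyl in place of 3-nitrophenyl giving an at least 5.1-fold lower number from compound 2 to compound 3 (0.71 log units; beyond the scatter). That step is only a lower bound, and compound 2 stands at a limit of the assay, not at a number: the limit of > 50000 nM in this assay, at which 1 of the 3 values shown sits.

On these data alone, what remains open is whether the gap between the two arylamino compounds follows the nitro group, the fluorine or the place on the ring, as 3-nitrophenyl and 4-fluorophenyl differ in both substituent and position, and a 4-nitrophenyl or 3-fluorophenyl group on the same nitrogen would separate these. Also open, as far as these compounds go, is what the hydrogen on that nitrogen contributes, a question that a methyl group on the nitrogen of the (4-fluorophenyl)amino group would address, while a morpholin-4-yl group would test the saturated ring of compound 1.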